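Swapping pyrrolidine for imidazole on a mouse agonist series

This account rests on a few compounds, and the source may have more. Where it says the series, first, only, none or still open, it means among the compounds named here.

Four closely related compounds share an alkyne-containing chain that ends in a small nitrogen ring. Compound 1, `COC(=O)N(C)C(C)C#CCN1CCCC1`, carries a pyrrolidin-1-yl ring at one end, while compound 2, `COC(=O)N(C)C(C)C#CCn1ccnc1`, has a 1H-imidazol-1-yl ring in that position. In a functional assay on the whole organism for agonist activity, with Mus musculus as the target (a higher number here means that more compound is needed for the effect, a lower number that less compound is needed), compound 1 gives 14.2 mg/kg. In this assay compound 2 gives 8 mg/kg. The change between them is 1H-imidazol-1-yl in place of pyrrolidin-1-yl on a saturated chain carbon bound to a triple-bonded carbon and it made a step of a 1.8-fold lower number from compound 1 to compound 2 (0.25 log units; within the scatter).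

Compound 3, `CN(C)C(=O)N(C)CC#CCN1CCCC1`, has a different core; the difference between the core of compound 1 and the core of compound 3 is not broken down here. For compound 3 in this assay only a limit is known, > 10 mg/kg, which is a boundary of the assay rather than a number. That limit, (the limit of > 10 mg/kg in this assay, at which 1 of the 3 values shown sits), is where one of the three reported values sits.

Compound 4, `CN(C)C(=O)N(C)CC#CCn1ccnc1`, has not yet been measured in this assay. Among the measured compounds shown here, it differs from compound 3 by 1H-imidazol-1-yl in place of pyrrolidin-1-yl on a saturated chain carbon bound to a triple-bonded carbon, the same kind of change as the one from compound 1 to compound 2. Since that earlier change gave a 1.8-fold lower number from compound 1 to compound 2 (0.25 log units; within the scatter), a similarly small step, a step that the limit leaves unreadable from compound 3 to compound 4, is expected from compound 3 to compound 4. On that basis compound 4 is estimated to fall near 12 mg/kg, with a likely range from 5 mg/kg to 30 mg/kg, and it may again be reported only as a limit.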

Compound 4, dose for half-maximal effect: 25.4 mg/kg
Compound 4: middle estimate off by 2.1-fold (0.33 log units), on the low side; measured number inside the range.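

The step from compound 3 to compound 4 cannot be read, because compound 3 is known only as a limit and not as a number: the limit of > 10 mg/kg in this assay, at which 1 of the 4 values shown sits.

The compounds shown leave open whether 1H-imidazol-1-yl in place of pyrrolidin-1-yl changes the dose needed on the core of compound 3, and whether any such change would match the one between compound 1 and compound 2.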